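This account rests on a few compounds, and the source may have more. Where it says the series, first, only, none or still open, it means among the compounds named here.

Measured compounds:
compound 1, `COc1cccc(/C=C2\CCC/C(=C\c3cccc(OC)c3OC)C2=O)c1` — 16400 nM
compound 2, `COc1ccc(/C=C2\CCC/C(=C\c3cccc(Br)c3)C2=O)cc1OC` — 12800 nM
compound 3, `COc1ccc(/C=C2\CCC/C(=C\c3ccc(OC)c(OC)c3)C2=O)c(OC)c1` — > 20000 nM

The three measured compounds share one core and differ only in the two aryl groups attached to it. In a functional assay on A549 cells (Homo sapiens) for cytotoxicity, read by MTT assay, with a stated time of 72 h (a higher number here means a weaker inhibitor, a lower number a stronger inhibitor), compound 1 gives 16400 nM. Compound 2 gives 12800 nM in this assay, the lowest of the two numbers shown, though compound 1 sits close enough that the two are within the scatter of repeated measurements. For compound 3 the result is a limit of the assay, > 20000 nM, and not a number; it stands at the limit of > 20000 nM in this assay, at which 1 of the 3 values shown sits.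

The step under consideration leads from compound 2 to compound 4, `COc1ccc(/C=C2\CCC/C(=C\c3ccc(O)c(Cl)c3)C2=O)cc1OC`, which has not been measured in this assay. The change is as follows: 3-chloro-4-hydroxyphenyl in place of 3-bromophenyl on a double-bonded chain carbon bound to a double-bonded ring carbon. Within the data shown here, no measured pair among the three compounds differs in one place only, so no step of known size is available as a guide; the measured values all sit at a weak level or at the limit.

On this basis the estimated step is a 1.6-fold lower number from compound 2 to compound 4 (0.20 log units; within the scatter), a modest improvement that is expected to lie within the scatter. Compound 4 is estimated at 8000 nM, with a range from 3000 nM to 25000 nM.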

Compound 4, half-maximal inhibitory concentration: > 20000 nM
Compound 4: only a limit was reported (the forecaster's own chance of this, stated with the estimate: 20%); at least 2.5-fold (0.39 log units) between middle value and limit.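

In this assay, putting 3-chloro-4-hydroxyphenyl in place of 3-bromophenyl on a double-bonded chain carbon bound to a double-bonded ring carbon gives the only step that can be read among these compounds: an at least 1.5-fold higher number from compound 2 to compound 4 (0.19 log units; that floor lies within the scatter). The result for compound 4 is a limit of the assay and not a number, so this step has a floor but no measured size, and that floor does not separate the two compounds beyond the scatter. The change therefore gives no sign of a gain at this position, and compound 4 joins compound 3 at the limit: the limit of > 20000 nM in this assay, at which 2 of the 4 values shown sit.

The compounds shown leave open which part of the change matters, since the bromine leaves and the chlorine and hydroxyl group enter in a single step, and an aryl group carrying only the chlorine or only the hydroxyl group would be needed to separate them. They also leave open whether an amine or a carboxylic acid on this aryl group would give a value that can be read in this assay, and with two of the four results at the limit, the lower end of the series remains undefined.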